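This account rests on a few compounds, and the source may have more. Where it says the series, first, only, none or still open, it means among the compounds named here.

Working notes on the series. In a functional assay on Ishikawa cells (Homo sapiens) for antiproliferative activity, read by CCK-8 assay, with a stated time of 48 h (on this read-out higher numbers stand for weaker inhibition and lower numbers for stronger inhibition), compound 1 `CNC(=O)/C=C/CN1CC(Oc2ccc(Oc3c(-c4ccc(F)cc4)sc4cc(O)ccc34)cc2)C1` gives > 25000 nM, which is a limit of the assay and not a number. Among the measured compounds shown here, compound 2 `CN(C)C(=O)/C=C/CN1CC(Oc2ccc(Oc3c(-c4ccc(F)cc4)sc4cc(O)ccc34)cc2)C1` gives 11200 nM, the only actual number so far, so its standing can be judged only against compound 1.

The next structure is compound 3 `C=CC(=O)N1CC(Oc2ccc(Oc3c(-c4ccc(F)cc4)sc4cc(O)ccc34)cc2)C1`. The change is vinylcarbonyl in place of 3-(dimethylcarbamoyl)prop-2-en-1-yl on an amine nitrogen in a ring of a four-membered non-aromatic ring.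

For the measured compounds named here, only one measured step is available: an at least 2.2-fold lower number from compound 1 to compound 2 (0.34 log units; beyond the scatter). That step is a methyl in place of hydrogen on an amide-type nitrogen, and compound 3 has no such amide-type nitrogen at all, so it bears on the present change only loosely. It shows that this series can respond to a small edit, but it gives neither size nor direction for replacing the whole group. No step beyond the scatter is therefore expected in this assay, with only a slight lean towards a lower number. The expected move is a 1.4-fold lower number from compound 2 to compound 3 (0.15 log units; within the scatter). For compound 3 the estimated value is 8000 nM, with an expected range of 2500 nM to 25000 nM.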

Compound 3, half-maximal inhibitory concentration: 12300 nM
Estimate against measurement, compound 3: 1.5-fold (0.19 log units) below, within the range that was stated.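

In this assay, vinylcarbonyl in place of 3-(dimethylcarbamoyl)prop-2-en-1-yl on the amine nitrogen in the four-membered non-aromatic ring gives a 1.1-fold higher number from compound 2 to compound 3 (0.04 log units; within the scatter), so compound 2 and compound 3 cannot be told apart here, although the group that enters has 4 heavy atoms and the one that leaves has 8. Against the methylcarbamoyl analogue, the reading is an at least 2.0-fold lower number from compound 1 to compound 3 (0.30 log units; that floor lies within the scatter), so this comparison gives only a floor and no true size for the step. The value of compound 1 is a limit of the assay and not a number, and that floor rests on it: the limit of > 25000 nM in this assay, at which 1 of the 3 values shown sits.

Still open, going by these compounds, is whether a group on this nitrogen with no carbonyl and no double bond, such as a plain methyl or a propyl chain ending in a dimethylamino group, would shift the number in this assay beyond the scatter. On these data alone, the core of compound 1 is shared by all three compounds, so the effect of replacing its hydroxyl or its 4-fluorophenyl group on this read-out also remains open.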